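The compounds below may be only part of what the source reports. "The series", "measured", "known", "first", "only" and "open" are said of these compounds alone.

Working notes on the series. Compound 2 `C#CCNC(=O)/C(C)=C(\C)c1ccc(OC)cc1` stands level with compound 3 `C#CCNC(=O)/C(C)=C(\C)c1ccc(Cl)cc1` at the lowest of the three numbers recorded in a toxicity assay on the whole organism (strain Icem-CET (SPF Caw)) for cytotoxicity, with Mus musculus as the target; a lower number here means that less compound is needed, a higher number that more compound is needed for the effect: compound 2 gives 400 mg/kg, compound 3 gives 400 mg/kg, and compound 1 `C=CCNC(=O)/C(C)=C(\C)c1ccc(Br)cc1` gives 500 mg/kg, a gap from compound 2 that lies within the scatter. The exchange no change at the digits printed from compound 2 to compound 3 (within the scatter) changes nothing beyond the scatter at the aromatic carbon. Compound 4 `C=CCNC(=O)/C(C)=C(\C)c1ccc(OC)cc1` differs from compound 2 by vinyl in place of ethynyl on a saturated chain carbon bound to an amide-type nitrogen. For the measured compounds named here, no measured pair isolates this exchange; compound 1 carries the vinyl chain but also a different aromatic substituent, so only its value can be set beside compound 2 and compound 3, and all three numbers lie close. Compound 4 is therefore expected to show a 1.1-fold higher number from compound 2 to compound 4 (0.05 log units; within the scatter), no step beyond the scatter, with an estimate of 450 mg/kg in this assay, ranging from 300 mg/kg to 700 mg/kg.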

Compound 4, dose for half-maximal effect: 300 mg/kg
Beside the measured number, compound 4's estimate is 1.5-fold (0.18 log units) above it, and the stated range covers the measured number.
By their numbers in this assay, from the lowest: compounds 4, 2, 3 and 1 (each within the scatter of the next).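

The exchange can now be read on its own in this assay: vinyl in place of ethynyl on a saturated chain carbon bound to an amide-type nitrogen gives a 1.3-fold lower number from compound 2 to compound 4 (0.12 log units; within the scatter). With the vinyl chain held constant, methoxy in place of bromo on an aromatic carbon gives a 1.7-fold lower number from compound 1 to compound 4 (0.22 log units; within the scatter). Neither step leaves the scatter, so neither place has yet shown a real difference in this series.

On these data alone, whether a longer chain or a chain ending in an amine or a carboxylic acid would move the number beyond the scatter stays open. Nothing available explains the numbers at hand.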